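Compound 3 to compound 4: benzylamino to piperidine

The source may report more compounds than this note shows. Statements on the series, on what has been measured and on what is new or still open speak of the compounds shown alone.

Going by the values given here, in a functional assay on A549 cells (Homo sapiens) for cytotoxicity, read by MTT assay, with a stated time of 48 h (a higher number here means a weaker inhibitor, a lower number a stronger inhibitor), compound 3 `COc1c(OCCCCNCc2ccccc2)cc(O)c2c(=O)cc(-c3ccccc3)oc12` gives 4590 nM, the only actual number so far. Compound 1 `COc1c(OCc2cnoc2C)cc(O)c2c(=O)cc(-c3ccccc3)oc12` reaches only a limit of the assay, > 100000 nM. For compound 2 `CCCCNCCOc1c(O)cc(O)c2c(=O)cc(-c3ccccc3)oc12` the result stands as "not determined" (no result reported).

Compound 4 `COc1c(OCCCCN2CCCCC2)cc(O)c2c(=O)cc(-c3ccccc3)oc12` carries piperidin-1-yl in place of benzylamino on a saturated chain carbon, four bonds along the chain from an oxygen on an aromatic ring.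

Among the compounds with values here, one measured step bears on this, and only indirectly. The step of an at least 21-fold lower number from compound 1 to compound 3 (1.33 log units; beyond the scatter) is large and shows that the group at this end of the substituent can matter in this assay. However, it replaces a different group and does not isolate the benzylamino-to-piperidine change. Compound 4 keeps the chain, so a moderate shift is more likely than a fall to the limit seen for compound 1. The expected step of a 1.7-fold higher number from compound 3 to compound 4 (0.24 log units; within the scatter) is towards a higher number, with wide uncertainty.

The estimated value for compound 4 is 8000 nM, with an expected range of 2000 nM to 35000 nM.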

Compound 4, half-maximal inhibitory concentration: 1150 nM
The estimate for compound 4 lay 7.0-fold (0.84 log units) above the measured number, and the stated range ends above it.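

In this assay, going by these compounds alone, the swap at the chain end gives a 4.0-fold lower number from compound 3 to compound 4 (0.60 log units; beyond the scatter), the first step between two amine-ending chains. Neither the six-membered aromatic ring of benzylamino nor its hydrogen-bond donor is needed here, since piperidin-1-yl has neither and the number still falls. Replacing 5-methyl-1,2-oxazol-4-yl with 3-(piperidin-1-yl)propyl gives an at least 86-fold lower number from compound 1 to compound 4 (1.93 log units; beyond the scatter), but this size is only a bound, with compound 1 resting on a limit rather than a number: the limit of > 100000 nM in this assay, at which 1 of the 4 values shown sits.

From the compounds shown here alone, whether the ring around the nitrogen matters in itself remains open, since a morpholine or a dimethylamino group at the chain end would separate ring from amine. Also open, going by these compounds, is how a shorter or longer chain carrying piperidin-1-yl would read.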